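Amide with a tetrazole tail replaces the acid of compound 1

This account rests on a few compounds, and the source may have more. Where it says the series, first, only, none or still open, it means among the compounds named here.

Measured so far:
- compound 1 `O=C(O)c1cc(-c2ccc(-c3ccc(Cl)cc3Cl)cc2)n(-c2cccnc2)n1`: 47000 nM
- compound 2 `O=C(O)c1cc(-c2ccc(-c3ccc(Cl)cc3Cl)cc2)n(Cc2ccncc2)n1`: 26200 nM

Both compounds were tested in an assay on isolated protein for inhibition of methionine--tRNA ligase, cytoplasmic (Homo sapiens); a lower number here means a stronger inhibitor, a higher number a weaker inhibitor. Compound 1 has the highest number of the two; its nearest neighbour is compound 2, and the step of a 1.8-fold lower number from compound 1 to compound 2 (0.25 log units; within the scatter) keeps both within the scatter. That step changes only the group on the aromatic nitrogen.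

Compound 3 `O=C(NCc1nn[nH]n1)c1cc(-c2ccc(-c3ccc(Cl)cc3Cl)cc2)n(-c2cccnc2)n1` differs from compound 1 at another place: ((2H-tetrazol-5-yl)methyl)amino in place of hydroxy on a carbonyl carbon. Among the compounds with values here, no measured step touches this carbonyl carbon, so the one step on record does not bear on it, and it also showed no change beyond the scatter. With nothing to point in either direction, the expectation for compound 3 is a number near that of compound 1, a step of a 1.2-fold lower number from compound 1 to compound 3 (0.07 log units; within the scatter) that stays within the scatter. Compound 3 is therefore estimated at 40000 nM, with a range from 10000 nM to 150000 nM.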

Compound 3, half-maximal inhibitory concentration: 13800 nM
For compound 3 the middle estimate is 2.9-fold (0.46 log units) above the measured one; measured number inside the range.
By their numbers in this assay, from the lowest: compounds 3, 2 and 1 (each within the scatter of the next, the first and the last beyond it).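

In this assay, the carbonyl carbon is the first place in the compounds shown where a change moves the number beyond the scatter (a 3.4-fold lower number from compound 1 to compound 3 (0.53 log units; beyond the scatter)). The step is modest, but it shows that the hydroxy of the carboxy group can be replaced by the much larger ((2H-tetrazol-5-yl)methyl)amino without losing inhibition, so within this pair the free acid is not required. No measurement here accounts for the gain.

The change brings in an amide nitrogen and a tetrazole ring together, so the step cannot be assigned to either alone; a simple methylamino group, or a carboxymethylamino group with a carboxylic acid in place of the tetrazole, would help to separate the two. On these data alone, it also remains open whether the same ((2H-tetrazol-5-yl)methyl)amino group gives a similar step when the aromatic nitrogen carries (pyridin-4-yl)methyl, as in compound 2.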